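A few compounds are considered here, and "the series" means these few. Any claim that something is new, unique, unknown or untested is made for them only; others in the source may bear on it.

Compound 2 `N#CC1=C(NC(N)=O)N(c2ccc(S(N)(=O)=O)cc2)C2=C(C(=O)CCC2)C1c1ccc(Cl)cc1Cl` gives 35% in a functional assay on Ehrlich cells (Mus musculus) for cytotoxicity, read by trypan blue exclusion, with a stated time of 2 h, tested at 25 ug/mL (on this read-out higher numbers stand for a stronger effect at the one concentration tested and lower numbers for a weaker effect), and compound 1 `C=CCNC(=S)NC1=C(C#N)C(c2ccc(Cl)cc2Cl)C2=C(CCCC2=O)N1c1ccc(S(N)(=O)=O)cc1` gives 30%, so the two stand together, separated only by a number 5 percentage points higher from compound 1 to compound 2 (within the scatter), which is within the scatter. Compound 3 `N#CC1=C(NS(=O)(=O)c2ccc([N+](=O)[O-])cc2)N(c2ccc(S(N)(=O)=O)cc2)C2=C(C(=O)CCC2)C1c1ccc(Cl)cc1Cl` carries (4-nitrophenyl)sulfonyl in place of carbamoyl on an amine nitrogen. Within the data shown here, the only measured step, a number 5 percentage points higher from compound 1 to compound 2 (within the scatter), also changed the group on that amine nitrogen and stayed within the scatter; nothing measured shows what a (4-nitrophenyl)sulfonyl does there. The expected step is therefore no change at the digits printed from compound 2 to compound 3 (within the scatter), none beyond the scatter. Compound 3 is expected to give 35%, ranging from 15% to 55%.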

Compound 3, a percentage reported as activity, at one concentration (the size of the read-out at that concentration, not a potency): 85%
Estimate against measurement, compound 3: 50 percentage points below; the whole stated range lies below it.
By their numbers in this assay, from the lowest: compounds 1 and 2 (each within the scatter of the next); then compound 3.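

On this amine nitrogen the choice of group can matter a great deal in this assay, which the first two compounds, standing within the scatter of each other, did not reveal. Among these compounds, putting (4-nitrophenyl)sulfonyl in place of carbamoyl brings a number 50 percentage points higher from compound 2 to compound 3 (beyond the scatter), and the same group in place of the one on compound 1 brings a number 55 percentage points higher from compound 1 to compound 3 (beyond the scatter). Nothing available explains this rise.

Still open, from the compounds shown here alone, is whether the sulfonyl or the 4-nitrophenyl part goes with the rise. A methylsulfonyl or a plain phenylsulfonyl group on this nitrogen would help separate the two.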